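A Methyl Branch Next to the Aryl Ether Oxygen

The source may report more compounds than this note shows. Statements on the series, on what has been measured and on what is new or still open speak of the compounds shown alone.

Compound 1 `CCCCCCCCc1ccc(OCC(=O)Cn2nnc(-c3ccc(Cl)cc3)n2)cc1`: 35 nM
Compound 2 `CCCCCCCCc1ccc(OCC(=O)Cn2nnc(-c3ccc(C(=O)OC)cc3)n2)cc1`: 29 nM
Compound 3 `CCCCCCCCc1ccc(OCC(=O)Cn2nnc(C(=O)OC)n2)cc1`: 88 nM

In an assay on microsomes from brain for inhibition of Fatty-acid amide hydrolase 1 (Rattus norvegicus), read by fluorescence and HPLC, with a stated time of 60 min (a lower number here means a stronger inhibitor, a higher number a weaker inhibitor), compound 2 gives 29 nM. Compound 1 and compound 2 sit within the scatter of each other (a 1.2-fold lower number from compound 1 to compound 2 (0.08 log units; within the scatter)), while compound 3 sits further off (a 3.0-fold higher number from compound 2 to compound 3 (0.48 log units; beyond the scatter) and a 2.5-fold higher number from compound 1 to compound 3 (0.40 log units; beyond the scatter)), so compound 2 holds one of the two close numbers at the low end.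

Compound 4 `CCCCCCCCc1ccc(OC(C)C(=O)Cn2nnc(-c3ccc(C(=O)OC)cc3)n2)cc1` differs from compound 2 by methyl in place of hydrogen on a saturated chain carbon bound to a carbonyl carbon and an oxygen on an aromatic ring. Among the measured compounds shown here, none of the measured steps touches that chain carbon: each of them exchanges the group on an aromatic carbon at the other end of the shared core, and even there the steps were small, one within the scatter and two modest. There is thus no direct guide, and the closest analogy, a single small group added to an otherwise unchanged core, suggests a step in this assay of no more than the scatter, in either direction.

Compound 4 is therefore expected to give 35 nM, with a range of 12 nM to 100 nM. The expected step of a 1.2-fold higher number from compound 2 to compound 4 (0.08 log units; within the scatter) is estimated to stay within the scatter.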

Compound 4, half-maximal inhibitory concentration: 25 nM
For compound 4 the middle estimate is 1.4-fold (0.15 log units) above the measured one; low and high end bracket the measured number.
By their numbers in this assay, from the lowest: compounds 4, 2 and 1 (each within the scatter of the next); then compound 3.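

Among the compounds shown here, every earlier step exchanged a group on an aromatic carbon, so this is the first look at the saturated chain carbon bound to a carbonyl carbon and an oxygen on an aromatic ring. In this assay, methyl in place of hydrogen at that carbon gives a 1.2-fold lower number from compound 2 to compound 4 (0.06 log units; within the scatter), so this position accepts a methyl with no change that can be told apart from repeat measurements. No measurement at hand says why the number holds steady.

Still open, from the compounds shown here alone, is whether this chain carbon would also accept something larger or different, such as an ethyl, a phenyl or a hydroxyl group. Going by these compounds, it is also open whether the same methyl would give so small a step with the 4-chlorophenyl of compound 1 in place of the 4-(methoxycarbonyl)phenyl.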